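The source may report more compounds than this note shows. Statements on the series, on what has been measured and on what is new or still open speak of the compounds shown alone.

In a functional assay on A2780 cells (Homo sapiens) for antiproliferative activity, read by MTT assay, with a stated time of 72 h (a lower number here means a stronger inhibitor, a higher number a weaker inhibitor), compound 1 (`COc1ccc(C2CC(c3ccc(F)cc3)=NN2C(=O)c2cc3ccccc3o2)cc1OC`) gives > 50 ug/mL as a limit of the assay, not a number. Going by the values given here, compound 2 (`Cc1ccc(C2CC(c3ccc(F)cc3)=NN2C(=O)c2cc3ccccc3o2)cc1`) gives > 50 ug/mL as a limit as well, so it has no numerical standing, and the limit of > 50 ug/mL in this assay, at which 2 of the 2 values shown sit, is all that can be said of the series so far. Among the compounds with values here, the only measured step is a step that the two limits leave unreadable from compound 1 to compound 2 and it offers no size to carry forward. Compound 3 (`O=C(c1cc2ccccc2o1)N1N=C(c2ccc(F)cc2)CC1c1ccc(F)cc1`) differs from compound 2 by one change: fluoro in place of methyl on an aromatic carbon that is, fluoro in place of methyl on an aromatic carbon, para to a large group. Within the data shown here, no measured step bears on this change, so no shift beyond the scatter is expected in this assay in either direction. The expected step is a step that the limit leaves unreadable from compound 2 to compound 3 and its size cannot be supported further. Compound 3 is estimated at 60 ug/mL with an expected range of 30 ug/mL to 120 ug/mL and will most likely be reported as a limit again.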

Compound 3, half-maximal inhibitory concentration: > 50 ug/mL
Compound 3 ended at the assay's limit (the forecaster's own chance of this, stated with the estimate: 85%); the middle value does not contradict the limit.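

In this assay, going by these compounds alone, compound 3 gives > 50 ug/mL as a limit and not a number, so no step among compound 1, compound 2 and compound 3 can be read: the limit of > 50 ug/mL in this assay, at which 3 of the 3 values shown sit.

The compounds shown leave open how far each lies from that limit, and whether the 3,4-dimethoxyphenyl, 4-methylphenyl and 4-fluorophenyl groups differ at all.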